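Fluoro to bromo: what to expect for compound 4

A few compounds are considered here, and "the series" means these few. Any claim that something is new, unique, unknown or untested is made for them only; others in the source may bear on it.

Measured in a functional assay on PC-3 cells (Homo sapiens) for inhibition, read by sulforhodamine B assay, with a stated time of 48 h; a higher number here means a weaker inhibitor of growth, a lower number a stronger inhibitor of growth:
compound 1 `CCOC(=O)c1nn(-c2ccccc2)c(-c2ccc(F)cc2)c1CNC(C)(C)C`: 69300 nM; 82100 nM (2 entries)
compound 2 `CCOC(=O)c1nn(-c2ccccc2)c(-c2ccc(Br)cc2)c1CNC(C)(C)C`: 15900 nM; > 509000 nM (2 entries)
compound 3 `CC(C)(C)NCc1c(C(=O)O)nn(-c2ccccc2)c1-c1ccc(F)cc1`: > 680000 nM (a limit)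

Compound 3 has no exact number and stands only at its limit of > 680000 nM (a limit of the assay, not a measurement). Compound 4 `CC(C)(C)NCc1c(C(=O)O)nn(-c2ccccc2)c1-c1ccc(Br)cc1` differs from it by a single swap: bromo in place of fluoro on an aromatic carbon. The same swap separates compound 1 from compound 2, but the entries of compound 2 disagree widely: 15900 nM; > 509000 nM (2 entries). That pair gives no firm guide, so no shift beyond the scatter is expected in this assay. The expected step of an at least 1.3-fold lower number from compound 3 to compound 4 (0.13 log units; that floor lies within the scatter) is therefore small. Compound 4 is estimated at 500000 nM within a range of 120000 nM to 900000 nM.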

Compound 4, concentration for 50% growth inhibition: > 585000 nM
Compound 4 ended at the assay's limit; the forecaster's own chance of this, stated with the estimate: 70%; middle value at least 1.1-fold (0.06 log units) away from the limit.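

Among the compounds shown here, compound 3 and compound 4 both stand only at limits of the assay, not at numbers, and no step between them can be read. As far as these compounds go, whether 4-fluorophenyl to 4-bromophenyl changes growth inhibition in this assay for this pair stays open.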